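One methyl added to an amine side chain

A few compounds are considered here, and "the series" means these few. Any claim that something is new, unique, unknown or untested is made for them only; others in the source may bear on it.

compound 1 `NCCCNc1c(C(=O)NCc2ccc(F)cc2)nc(Br)c2cccnc12` reported as "not determined" (no result reported)
compound 2 `N[C@H]1CC[C@H](NC(=O)c2nc(Br)c3cccnc3c2NCc2ccc(F)cc2)CC1` reported as 2800 nM
compound 3 `N[C@H]1CC[C@H](Nc2c(C(=O)NCc3ccc(Cl)cc3)nc(Br)c3cccnc23)CC1` reported as 2000 nM

In a functional assay on SK-BR-3 cells (Homo sapiens) for cytotoxicity, read by MTT assay, with a stated time of 72 h (on this read-out lower numbers stand for stronger inhibition and higher numbers for weaker inhibition), compound 1 has no number to stand on, its entry reading "not determined" (no result reported) and offering no anchor. Compound 4 `CNCCCNc1c(C(=O)NCc2ccc(F)cc2)nc(Br)c2cccnc12` differs from it by one change, (methyl in place of hydrogen on an amine nitrogen), methyl in place of hydrogen on an amine nitrogen. Among the compounds with values here, no measured pair shows this change, so a step no larger than the scatter is expected in this assay, with no direction favoured. Within the data shown here, the only numbers available are those of compound 2 at 2800 nM and compound 3 at 2000 nM, which lie within the scatter of each other and differ from compound 1 in more than one place. Compound 4 is therefore expected near 2200 nM, with an estimated range from 700 nM to 7000 nM in this measurement.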

Compound 4, half-maximal inhibitory concentration: 1000 nM
Estimate against measurement, compound 4: 2.2-fold (0.34 log units) above, and the stated range covers the measured number.
By their numbers in this assay, from the lowest: compounds 4, 3 and 2 (each within the scatter of the next, the first and the last beyond it).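

The pair of compound 1 and compound 4 yields no readable step in this assay. The compounds shown leave open what methyl in place of hydrogen on an amine nitrogen does to this read-out. No evidence bears on the result.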